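Adding a Hydroxy Group to the Sugar of Compound 2

A few compounds are considered here, and "the series" means these few. Any claim that something is new, unique, unknown or untested is made for them only; others in the source may bear on it.

Of the compounds shown here, two have so far been tested in a functional assay on HeLa cells (Homo sapiens) for inhibition; a lower number here means a stronger inhibitor, a higher number a weaker inhibitor. Compound 1 `Cc1cn(/C=C/CO)c(=O)[nH]c1=O` reaches only the limit of the assay, > 100000 nM, so no number is known for it. Compound 2 `Cc1cn([C@H]2C[C@H](O)[C@@H](CO)O2)c(=O)n(/C=C/C=O)c1=O` gives 15000 nM in this assay. Among the compounds with values here, that is the only real number available, since the one other result, (the limit of > 100000 nM in this assay, at which 1 of the 2 values shown sits), is a limit rather than a measurement. Compound 3 `Cc1cn([C@@H]2O[C@H](CO)[C@@H](O)[C@H]2O)c(=O)n(/C=C/C=O)c1=O` has not yet been measured in this assay. It differs from compound 2 by hydroxy in place of hydrogen on a saturated ring carbon. Within the data shown here, no measured pair shows what such a change does in this assay, so the size of the step cannot be read from the data. The step of a 2.0-fold higher number from compound 2 to compound 3 (0.30 log units; within the scatter) is expected to be modest and toward weaker inhibition, though it may fall within the usual scatter. For compound 3 an inhibitory concentration of 30000 nM is estimated, within a range from 8000 nM to 150000 nM, and a result reported only as a limit is also possible.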

Compound 3, half-maximal inhibitory concentration: > 100000 nM
Compound 3: no number, only a limit; the forecaster's own chance of this, stated with the estimate: 35%; middle value at least 3.3-fold (0.52 log units) away from the limit.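

Hydroxy in place of hydrogen on this saturated ring carbon gives the first readable step in this assay: an at least 6.6-fold higher number from compound 2 to compound 3 (0.82 log units; beyond the scatter). The step shows that this small change to the sugar ring, made on a ring carbon next to the ring atom that bears a hydroxy group, goes with clearly weaker inhibition in this pair, and the shift is not lost in the scatter. On these data alone, its full size is unknown, since the result for compound 3 is a limit and the step gives only a minimum, and such limits are common in this small set: the limit of > 100000 nM in this assay, at which 2 of the 3 values shown sit.

One pair cannot show whether the weakening comes from the hydroxy group specifically or from any added group at this position. A methoxy group, a fluorine atom or an amine on the same carbon would help to separate these possibilities.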